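A few compounds are considered here, and "the series" means these few. Any claim that something is new, unique, unknown or untested is made for them only; others in the source may bear on it.

Of the compounds shown here, three built on one shared core have been measured in an assay on isolated protein for inhibition of 2-Hydroxyacid oxidase 2 (Homo sapiens), tested at 10 uM; on this read-out lower numbers stand for a weaker effect and higher numbers for a stronger effect at the one concentration tested. Compound 1 `Cc1n[nH]c(C(=O)O)c1Cc1cccc(C(F)(F)F)c1` gives 23% in this assay, the lowest of the three numbers. Compound 3 `Cc1n[nH]c(C(=O)O)c1Cc1ccc(Oc2ccccc2)cc1` gives 43% in this assay, and compound 2 `Cc1n[nH]c(C(=O)O)c1Cc1cccc2ccccc12` gives 59% in this assay. Compound 1 therefore stands below both of the others by more than the usual scatter, with compound 3 the nearer of the two and compound 2 the further.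

Compound 4 `Cc1n[nH]c(C(=O)O)c1Cc1cccc(-c2ccccc2F)c1` has not yet been measured. It differs from compound 1 in a single place: 2-fluorophenyl in place of trifluoromethyl on an aromatic carbon. Going by the values given here, no pair of measured compounds differs in only one place, so the size of this step cannot be read from the data; still, a step upward is expected, because compound 2 gives 59% and compound 3 gives 43% while compound 1 sits lowest. The expected step in this assay is a number 22 percentage points higher from compound 1 to compound 4 (beyond the scatter). Compound 4 is estimated to give 45% in this assay, with a range from 25% to 65%.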

Compound 4, a percentage reported as inhibition, at one concentration (the size of the read-out at that concentration, not a potency): 22%
Compound 4: middle estimate off by 23 percentage points, on the high side; the whole stated range lies above it.
By their numbers in this assay, from the lowest: compounds 4 and 1 (each within the scatter of the next); then compound 3; then compound 2.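

Going by these compounds alone, at this place, on an aromatic carbon meta to a large group, the first one-place step reads in this assay as a number 1 percentage points lower from compound 1 to compound 4 (within the scatter). Going from trifluoromethyl with 4 heavy atoms to 2-fluorophenyl with 7 heavy atoms and a six-membered aromatic ring therefore gives two numbers that this read-out cannot separate, so adding that ring here brings no visible gain. Nothing available explains why the two groups read alike.

Going by these compounds, neither group carries a hydrogen-bond donor or acceptor, so it remains open whether an amine, a hydroxyl or a carboxylic acid at this place would move the number beyond the scatter. On these data alone, it is also open whether a plain phenyl, without the fluorine, would read any differently from 2-fluorophenyl.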